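Swapping methoxy for isopropoxy on a cytotoxic series

The compounds below may be only part of what the source reports. "The series", "measured", "known", "first", "only" and "open" are said of these compounds alone.

Compound 1 `C[S+]([O-])/C=C/c1cc(=O)c2ccccc2o1` gives 1900 nM
Compound 2 `CC(C)C(=O)Oc1ccc2oc(/C=C/[S+](C)[O-])cc(=O)c2c1` gives 2400 nM
Compound 3 `COc1ccc2oc(/C=C/[S+](C)[O-])cc(=O)c2c1` gives 1600 nM

All three were measured in a functional assay on A549 cells (Homo sapiens) for cytotoxicity, with a stated time of 48 h; on this read-out higher numbers stand for weaker inhibition and lower numbers for stronger inhibition. Compound 3 stands level with the other two, since the gaps separating it from them, a 1.2-fold lower number from compound 1 to compound 3 (0.07 log units; within the scatter) and a 1.5-fold lower number from compound 2 to compound 3 (0.18 log units; within the scatter), do not exceed the ordinary scatter of the measurement.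

The next compound, compound 4 `CC(C)Oc1ccc2oc(/C=C/[S+](C)[O-])cc(=O)c2c1`, alters one group: isopropyl in place of methyl on an oxygen on an aromatic ring. Methoxy thus becomes isopropoxy. Among the compounds with values here, no measured pair makes exactly this change. The closest guide is the swap already seen on that oxygen, a 1.5-fold lower number from compound 2 to compound 3 (0.18 log units; within the scatter). Adding a group to the bare core gave a 1.3-fold higher number from compound 1 to compound 2 (0.10 log units; within the scatter), again within the scatter. None of the three measured steps goes beyond the scatter, so no step beyond it is expected here either.

The expected step is a 1.1-fold higher number from compound 3 to compound 4 (0.05 log units; within the scatter). The estimated value for compound 4 is 1800 nM, with an expected range from 900 nM to 3600 nM.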

Compound 4, half-maximal inhibitory concentration: 1500 nM
Estimate against measurement, compound 4: 1.2-fold (0.08 log units) above; the measured number falls inside the stated range.
By their numbers in this assay, from the lowest: compounds 4, 3, 1 and 2 (each within the scatter of the next).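

At this oxygen on an aromatic ring, isopropyl in place of methyl brings 3 heavy atoms where there was 1, yet the two compounds remain level in this assay (a 1.1-fold lower number from compound 3 to compound 4 (0.03 log units; within the scatter)). Isopropoxy also stands level with the isopropylcarbonyl group on the same oxygen (a 1.6-fold lower number from compound 2 to compound 4 (0.20 log units; within the scatter)) and with plain hydrogen on the aromatic carbon (a 1.3-fold lower number from compound 1 to compound 4 (0.10 log units; within the scatter)), so across these four compounds, neither adding a group at this place nor changing its size or type has yet produced a step beyond the scatter. Nothing available here offers an explanation for this flat result.

From the compounds shown here alone, it remains open whether a longer chain, an amine or a carboxylic acid at this place would move the number beyond the scatter. Going by these compounds, the effect of changes elsewhere on the shared core also remains open.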